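The source may hold more compounds than are shown below. What is called first, only, known or untested is meant among the compounds shown, and "the series" means these compounds.

Compound 3, `CC[C@@H]1C(=O)N(C)c2cnc(-n3ccc4cc(C(=O)NC(C)C)ccc43)nc2N1C1CCCC1`, is examined in a functional assay on NCI-H1975 cells (Homo sapiens) for antiproliferative activity, read by CCK-8 assay, with a stated time of 72 h (a lower number here means a stronger inhibitor of growth, a higher number a weaker inhibitor of growth), where compound 3 gives 1840 nM. Among the three compounds measured so far this places compound 3 second highest. The nearest number belongs to compound 1, `CC[C@@H]1C(=O)N(C)c2cnc(Nc3ccc(S(=O)(=O)NC4CCCC4)cc3)nc2N1C1CCCC1`, which in this assay gives 1710 nM, a value within the scatter of that of compound 3. The furthest number belongs to compound 2, `CCC1C(=O)N(C)c2cnc(Nc3ccc(S(=O)(=O)NCC(C)C)cc3)nc2N1c1ccn(C)n1`, which in this assay gives 15000 nM, a weaker inhibition than compound 3 that lies beyond the scatter.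

The step under consideration leads from compound 3 to compound 4, `CC[C@@H]1C(=O)N(C)c2cnc(-n3ccc4cc(C(=O)NC5CCCC5)ccc43)nc2N1C1CCCC1`. The two structures differ in one place: cyclopentyl in place of isopropyl on an amide-type nitrogen. Among the compounds with values here, no measured pair in the set shows this particular change on its own, so its effect cannot be read from a recorded step.

An amide-bound cyclopentyl in place of an isopropyl is a modest enlargement, and no evidence in the set points in either direction. Compound 4 is therefore expected to give about 1500 nM in this assay, with a plausible range from 500 nM to 4500 nM. The expected step of a 1.2-fold lower number from compound 3 to compound 4 (0.09 log units; within the scatter) is estimated to stay within the usual scatter.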

Compound 4, concentration for 50% growth inhibition: 856 nM
Beside the measured number, compound 4's estimate is 1.8-fold (0.24 log units) above it, within the range that was stated.
By their numbers in this assay, from the lowest: compounds 4, 1 and 3 (each within the scatter of the next, the first and the last beyond it); then compound 2.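

Within the data shown here, the change from isopropyl to cyclopentyl on the amide-type nitrogen gives, in this assay, a 2.1-fold lower number from compound 3 to compound 4 (0.33 log units; beyond the scatter) as the first step that can be read at this position. The earlier compounds shown here could not show this, since none of them differs from another in one place. The step shows that this position responds to the group carried on the nitrogen and that, for this single pair, the all-carbon ring gives the lower number, though only by a modest margin, and nothing in the data accounts for the shift.

As far as these compounds go, it remains open whether a cyclohexyl or a tert-butyl group on this nitrogen would extend the step, or whether a smaller methyl would reverse it. A piperidine ring or a chain ending in a carboxylic acid at the same place is equally untested by the compounds shown here.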